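A few compounds are considered here, and "the series" means these few. Any claim that something is new, unique, unknown or untested is made for them only; others in the source may bear on it.

Working notes on the series. In a functional assay on MCF7 cells (Homo sapiens) for cytotoxicity, read by MTT assay, with a stated time of 72 h (on this read-out lower numbers stand for stronger inhibition and higher numbers for weaker inhibition), compound 1 `Cc1ccc(-n2nc(C(=O)Nc3ccc(Oc4ncnc5ccsc45)cc3)c(C)cc2=O)cc1` gives 23800 nM. Compound 2 `Cc1cc(=O)n(-c2cccc(F)c2)nc1C(=O)Nc1ccc(Oc2ncnc3ccsc23)c(F)c1` gives 9050 nM in this assay, and compound 3 `Cc1ccc(-n2nc(C(=O)Nc3ccc(Oc4ncnc5ccsc45)c(F)c3)c(C)cc2=O)cc1` gives 7250 nM, the lowest of the three numbers. The step of a 3.3-fold lower number from compound 1 to compound 3 (0.52 log units; beyond the scatter) is the only one beyond the scatter; the step of a 1.2-fold lower number from compound 2 to compound 3 (0.10 log units; within the scatter) is not.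

Compound 4 `Cc1ccc(-n2nc(C(=O)Nc3ccc(Oc4ncnc5sccc45)c(F)c3)c(C)cc2=O)cc1` keeps the same atoms as compound 3, joined differently: a group of 9 heavy atoms (6 carbon, 2 nitrogen, 1 sulfur; one five-membered aromatic ring with 1 hetero atom, one six-membered aromatic ring with 2 hetero atoms) in place of a group of 9 heavy atoms (6 carbon, 2 nitrogen, 1 sulfur; one five-membered aromatic ring with 1 hetero atom, one six-membered aromatic ring with 2 hetero atoms), on an oxygen on an aromatic ring. Going by the values given here, neither measured step touches this part of the molecule, so no step in this assay bears on the change. No step beyond the scatter is therefore expected. Compound 4 is estimated at 7500 nM in this assay, between 3000 nM and 20000 nM. The estimated step is a 1.0-fold higher number from compound 3 to compound 4 (0.01 log units; within the scatter), within the scatter.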

Compound 4, half-maximal inhibitory concentration: > 40000 nM
Compound 4: a limit, no number (the forecaster's own chance of this, stated with the estimate: 5%); middle value at least 5.3-fold (0.72 log units) from the limit.
By their numbers in this assay, from the lowest: compounds 3 and 2 (each within the scatter of the next); then compound 1. At a limit, above all of these: compound 4.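

Going by these compounds alone, with the atoms unchanged and the counted features of the group on the oxygen identical, the rearrangement alone gives an at least 5.5-fold higher number from compound 3 to compound 4 (0.74 log units; beyond the scatter) in this assay and so shows what no earlier compound could: the way this group is joined matters here. Compound 4 reads > 40000 nM as a limit of the assay and not a number. The step is therefore a bound only, its full size unread: the limit of > 40000 nM in this assay, at which 1 of the 4 values shown sits.

Open, from the compounds shown here alone, is whether the same rearrangement costs as much with the 3-fluorophenyl of compound 2 or without the fluoro of compound 1. Also open, going by these compounds, is what an amine on the five-membered aromatic ring would do to the read-out.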